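Cytotoxicity notes on the amide-nitrogen substituent series

The source may report more compounds than this note shows. Statements on the series, on what has been measured and on what is new or still open speak of the compounds shown alone.

The series shares the core of compound 1 `COc1ccc([C@H]2CC(=O)N(C(C)=O)C2)cc1OC1CCCC1` and varies the group on the amide-type nitrogen in the ring. In a functional assay on HEK293 cells (Homo sapiens) for cytotoxicity (on this read-out lower numbers stand for higher toxicity in this test and higher numbers for lower toxicity in this test), compound 1 reaches only > 10000 nM, which is a limit of the assay and not a number. Compound 2 `COc1ccc([C@H]2CC(=O)N(c3cccc(N(C)C)c3)C2)cc1OC1CCCC1` carries 3-(dimethylamino)phenyl on that nitrogen. In this assay compound 2 also stops at a limit, > 10000 nM. Compound 3 `COc1ccc([C@H]2CC(=O)N(c3ccccc3C)C2)cc1OC1CCCC1` carries 2-methylphenyl on that nitrogen. In this assay compound 3 likewise returns a limit, > 10000 nM. The steps a step that the two limits leave unreadable from compound 1 to compound 2, a step that the two limits leave unreadable from compound 1 to compound 3 and a step that the two limits leave unreadable from compound 2 to compound 3 therefore cannot be sized; the common ground is the limit of > 10000 nM in this assay, at which 3 of the 3 values shown sit.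

Compound 4 `COc1ccc([C@H]2CC(=O)N(c3cccc(NS(=O)(=O)c4cccc(Cl)c4C)c3)C2)cc1OC1CCCC1` differs from compound 2 in one place: ((3-chloro-2-methylphenyl)sulfonyl)amino in place of dimethylamino on an aromatic carbon. Within the data shown here, no measured step exchanges a substituent on this aromatic ring, so none bears on the change directly; the three measured compounds, all at the limit, are the only guide. The expectation for compound 4 is a step of a number no higher from compound 2 to compound 4 (the limit leaves the size open), which is no step beyond the scatter, with a limit again the most likely outcome. Compound 4 is estimated at 10000 nM, within 3000 nM to 30000 nM.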

Compound 4, half-maximal cytotoxic concentration: > 10000 nM
Compound 4: no number, only a limit; the forecaster's own chance of this, stated with the estimate: 65%; the middle value sits exactly at the limit.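

Compound 2 and compound 4 both stop at a limit of the assay in this assay, not at a number, so no new step can be read between them. The compounds shown leave open whether any group on the amide-type nitrogen, or on the aromatic ring it carries, would give a readable number in this assay.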